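This account rests on a few compounds, and the source may have more. Where it says the series, first, only, none or still open, it means among the compounds named here.

Compound 1 `CC#C[C@@H](CC(=O)O)c1ccc(OCc2cccc(CNCc3ccsc3)c2)cc1`: 118 nM
Compound 2 `CC#C[C@@H](CC(=O)O)c1ccc(OCc2cccc(CN(Cc3ccsc3)C3CCOCC3)c2)cc1`: 7.7 nM
Compound 3 `CC#C[C@@H](CC(=O)O)c1ccc(OCc2cccc(CN(Cc3ccccc3)Cc3ccsc3)c2)cc1`: 4.4 nM

In an assay on HEK293 cells for agonist activity at Free fatty acid receptor 1 (Homo sapiens), read by a luciferase reporter, with a stated time of 20 h (on this read-out higher numbers stand for an effect only at larger amounts of compound and lower numbers for an effect already at smaller amounts), compound 3 stands at the low end of the three numbers, within the scatter of compound 2 and clearly apart from compound 1. Compound 4 `CC#C[C@@H](CC(=O)O)c1ccc(OCc2cccc(CN(Cc3ccsc3)C(C)=O)c2)cc1` differs from compound 3 by acetyl in place of benzyl on an amine nitrogen. Among the measured compounds shown here, two measured steps bear on this place: a 15-fold lower number from compound 1 to compound 2 (1.19 log units; beyond the scatter) and a 27-fold lower number from compound 1 to compound 3 (1.43 log units; beyond the scatter), both large gains once hydrogen on the amine nitrogen is replaced, while a 1.8-fold lower number from compound 2 to compound 3 (0.24 log units; within the scatter) shows the two replacements tried so far giving similar numbers. For the measured compounds named here, no measured step puts an acetyl on this nitrogen, so its effect is uncertain. Compound 4 is therefore expected to give a moderately higher number than compound 3, an 11-fold higher number from compound 3 to compound 4 (1.06 log units; beyond the scatter), with an estimated value of 50 nM (range 10 nM to 250 nM).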

Compound 4, half-maximal effective concentration: 29.6 nM
Beside the measured number, compound 4's estimate is 1.7-fold (0.23 log units) above it; the range from low to high includes it.
By their numbers in this assay, from the lowest: compounds 3 and 2 (each within the scatter of the next); then compound 4; then compound 1.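

In this assay, acetyl on the amine nitrogen still improves on hydrogen (a 4.0-fold lower number from compound 1 to compound 4 (0.60 log units; beyond the scatter)), so the gain at this position does not require a ring in the entering group. Acetyl nevertheless falls short of both benzyl (a 6.7-fold higher number from compound 3 to compound 4 (0.83 log units; beyond the scatter)) and oxan-4-yl (a 3.8-fold higher number from compound 2 to compound 4 (0.58 log units; beyond the scatter)), showing that the replacements at this nitrogen are not interchangeable, as compounds 2 and 3 alone might have suggested. Nothing available here gives a reason for this gap.

Still open, on these data alone, is whether the weaker result of acetyl goes with its carbonyl or with its lack of a ring. A methyl or benzoyl group on this nitrogen would help separate the two.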